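Replacing a hydroxymethyl arm with a plain carbon chain

This account rests on a few compounds, and the source may have more. Where it says the series, first, only, none or still open, it means among the compounds named here.

In a functional assay on HeLa cells (Homo sapiens) for cytotoxicity, read by WST assay, with a stated time of 48 h; on this read-out lower numbers stand for stronger inhibition and higher numbers for weaker inhibition:
Compound 1 `COc1cc(C(c2ccc(O)c(OC)c2)[C@H](CF)C(C)C)ccc1O`: 19000 nM
Compound 2 `CCCCCCCC[C@H](C(C)C)C(c1ccc(O)c(OC)c1)c1ccc(O)c(OC)c1`: 3100 nM
Compound 3 `COc1cc(C(c2ccc(O)c(OC)c2)[C@H](C)[C@@H](C)CO)ccc1O`: > 100000 nM (a limit, not a number)

As far as these compounds go, compound 3 stands at the limit of > 100000 nM in this assay, at which 1 of the 3 values shown sits, so its true position on the scale is unknown. Compound 4 `CCCCC[C@H](C(C)C)C(c1ccc(O)c(OC)c1)c1ccc(O)c(OC)c1` has not been measured yet. It differs from compound 3 by 1-isopropylhexyl in place of 2-(hydroxymethyl)-1-methylpropyl on a saturated chain carbon bound to two aromatic carbons: 1-isopropylhexyl in place of 2-(hydroxymethyl)-1-methylpropyl.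

For the measured compounds named here, two measured steps bear on this change. Heptyl in place of fluoro gave a 6.1-fold lower number from compound 1 to compound 2 (0.79 log units; beyond the scatter). The group now leaving, when it entered, gave an at least 5.2-fold higher number from compound 1 to compound 3 (0.72 log units; beyond the scatter). Both steps point the same way, so a clearly lower number is expected in this assay.

The estimated move is an at least 16-fold lower number from compound 3 to compound 4 (1.22 log units; beyond the scatter).

For compound 4 the estimate is 6000 nM, with an expected range of 2000 nM to 20000 nM.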

Compound 4, half-maximal inhibitory concentration: 9200 nM
Compound 4: middle estimate off by 1.5-fold (0.19 log units), on the low side; the measured number falls inside the stated range.
By their numbers in this assay, from the lowest: compound 2; then compound 4; then compound 1. At a limit, above all of these: compound 3.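

Compound 3 gives only a limit in this assay, > 100000 nM. Putting 1-isopropylhexyl, which carries no hydrogen-bond donor, at this saturated chain carbon brings a measurable value, with an at least 10-fold lower number from compound 3 to compound 4 (1.03 log units; beyond the scatter). Chain length also matters: the shorter chain gives a 3.0-fold higher number from compound 2 to compound 4 (0.47 log units; beyond the scatter), yet it still improves on the fluoro compound, with a 2.1-fold lower number from compound 1 to compound 4 (0.31 log units; beyond the scatter).

In the step to compound 4, the hydroxyl leaves and the carbon count grows together, so their separate contributions remain unresolved. As far as these compounds go, whether a longer chain would lower the number further, or an amine on the chain would be tolerated, stays open.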